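Lengthening the ether chain: working notes

A few compounds are considered here, and "the series" means these few. Any claim that something is new, unique, unknown or untested is made for them only; others in the source may bear on it.

All values below come from a functional assay on L1210 cells (Mus musculus) (a higher number here means a weaker inhibitor, a lower number a stronger inhibitor), alone:

- compound 1 (`COC[C@H]1OC(n2c(Cl)nc3cc(Cl)c(Cl)cc32)[C@H](O)[C@@H]1O`) gives 60000 nM
- compound 2 (`CCOC[C@H]1OC(n2c(Cl)nc3cc(Cl)c(Cl)cc32)[C@H](O)[C@@H]1O`) gives 59000 nM

Going by the values given here, compound 2 has only one measured neighbour, and the two stand level: the gap is a 1.0-fold lower number from compound 1 to compound 2 (0.01 log units; within the scatter) and no order can be read from it. The next entry is compound 3 (`CCCCOC[C@H]1OC(n2c(Cl)nc3cc(Cl)c(Cl)cc32)[C@H](O)[C@@H]1O`), where the change from compound 2 is ethyl in place of hydrogen on a saturated chain carbon, two bonds along the chain from an oxygen on a saturated carbon and turns ethoxy into butoxy. It sits on a saturated chain carbon, two bonds along the chain from an oxygen on a saturated carbon.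

Only the methyl-for-hydrogen step on the same ether chain bears on this. That step stayed within the scatter, which is thin evidence for an ethyl addition. In this assay no step beyond the scatter is therefore expected, in either direction. The expected change is a 1.1-fold lower number from compound 2 to compound 3 (0.03 log units; within the scatter) as an estimate. Compound 3 is estimated at 55000 nM with 25000 nM to 110000 nM as the expected range.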

Compound 3, half-maximal inhibitory concentration: > 100000 nM
Compound 3 ended at the assay's limit; the forecaster's own chance of this, stated with the estimate: 10%; at least 1.8-fold (0.25 log units) between middle value and limit.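

In this assay compound 3 gives > 100000 nM, which is a limit of the assay and not a number: the limit of > 100000 nM in this assay, at which 1 of the 3 values shown sits.

Read against the ethoxy ether, the ethyl addition on the saturated chain carbon, two bonds along the chain from an oxygen on a saturated carbon, gives an at least 1.6-fold higher number from compound 2 to compound 3 (0.22 log units; that floor lies within the scatter), and the propyl-for-hydrogen change gives an at least 1.6-fold higher number from compound 1 to compound 3 (0.22 log units; that floor lies within the scatter). Both are floors rather than measured sizes, and each floor lies within the scatter, so the true step could be that small or much larger. What this adds to the level pair of compound 1 and compound 2 is a direction only: the butoxy chain brings no lower number, while a real loss of strength beyond the scatter can be neither claimed nor excluded.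

On these data alone, whether a propoxy chain stays level with compound 2 or already reaches the limit remains open. Also open, as far as these compounds go, is how a chain ending in an amine or a carboxylic acid, rather than in plain alkyl, would read in this assay.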